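Chloro-substitution pattern on the shared core and growth inhibition

The source may report more compounds than this note shows. Statements on the series, on what has been measured and on what is new or still open speak of the compounds shown alone.

Measured compounds:
Compound 1 `O=c1c(C2N=C(c3ccccc3)SS2)coc2ccc(Cl)cc12`: 69%
Compound 2 `O=c1c(C2N=C(c3ccccc3)SS2)coc2cc(Cl)c(Cl)cc12`: 51%
Compound 3 `O=c1c(C2N=C(c3ccccc3)SS2)coc2ccc(F)cc12`: 51%

In a functional assay on HEp-2 cells (Homo sapiens) for inhibition, read by sulforhodamine B assay, with a stated time of 48 h, tested at 100 uM (on this read-out higher numbers stand for more inhibition of growth at the one concentration tested and lower numbers for less inhibition of growth), compound 1 gives 69%. Compound 2 gives 51%, level with compound 3 at the digits shown, and the two stand together as the lowest of the three numbers; the step of a number 18 percentage points lower from compound 1 to compound 2 (beyond the scatter) is the only one that separates compound 2 from another compound beyond the scatter. The unmeasured compound 4 `O=c1c(C2N=C(c3ccccc3)SS2)coc2cc(Cl)ccc12` differs from compound 2 by hydrogen in place of chloro on an aromatic carbon. The measured step that bears on it is a number 18 percentage points lower from compound 1 to compound 2 (beyond the scatter), a chloro entering on the core, which moved the number down by a modest amount; the step of a number 18 percentage points lower from compound 1 to compound 3 (beyond the scatter) concerns a swap of halogen and bears only loosely. Removing a chloro from compound 2 runs the change of the first step backwards, though at a different place on the ring, so a modest rise in this assay is expected rather than a fall. Compound 4 is therefore estimated at 62%, within 45% to 78%. The estimate amounts to an expected step of a number 11 percentage points higher from compound 2 to compound 4 (beyond the scatter).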

Compound 4, percent growth inhibition at one concentration: 31%
Compound 4: middle estimate off by 31 percentage points, on the high side; the measured number lies below the stated range.
By their numbers in this assay, from the lowest: compound 4; then compounds 2 and 3 (each within the scatter of the next); then compound 1.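

Chloro on the aromatic carbon ortho to a chloro group, meta to a fused ring and para to a fused ring, counts in this assay: hydrogen in its place gives a number 20 percentage points lower from compound 2 to compound 4 (beyond the scatter), the opposite of the rise that reversing a chloro addition might suggest. Adding a chloro gave a number 18 percentage points lower from compound 1 to compound 2 (beyond the scatter) and removing this chloro from compound 2 also lowers the number, so in this pair of steps chloro entering and chloro leaving do not act as opposites, and the place of the chloro matters. No measured evidence on the series accounts for this fall.

Still open, on these data alone, is how a methoxy group, a methyl group or an amine would read at this place. Also open, as far as these compounds go, is whether bromo would hold the number of compound 2 at 51% on the same core.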